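Swapping the anilino substituent for a benzylamine on the triazole

The source may report more compounds than this note shows. Statements on the series, on what has been measured and on what is new or still open speak of the compounds shown alone.

Measured compounds:
compound 1, `COc1cccc(Nc2n[nH]c(-c3cccnc3Nc3cc(OC)cc(OC)c3)n2)c1`, 72%
compound 2, `COc1cc(Nc2ncccc2-c2n[nH]c(Nc3ccccc3)n2)cc(OC)c1`, 22%

Of the compounds shown here, two have been measured in a functional assay on A-431 cells (Homo sapiens), tested at 0.1 uM; a lower number here means less inhibition, a higher number more inhibition at the concentration tested (going by the name of the read-out). Compound 1 gives 72%, the higher of the two numbers. Compound 2, in which the two aryl amines exchange their places on the shared core, gives 22% in this assay; the gap between the two values lies well beyond the scatter of this kind of measurement, so compound 1 stands clearly above compound 2 on the numbers shown.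

Compound 3, `COc1ccc(CNc2n[nH]c(-c3cccnc3Nc3cc(OC)cc(OC)c3)n2)cc1`, has not yet been measured. It differs from compound 1 in one place: 4-methoxybenzyl in place of 3-methoxyphenyl on a nitrogen on an aromatic ring. The change keeps the single aromatic ring and the single hydrogen-bond acceptor but inserts one more carbon between the ring and the nitrogen on the aromatic ring.

Going by the values given here, no step between measured compounds speaks to this change. A moderate decrease in this assay is expected for compound 3, a step of a number 22 percentage points lower from compound 1 to compound 3 (beyond the scatter), and the estimate for compound 3 is 50% with a range from 20% to 80%.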

Compound 3, a percentage reported as inhibition, at one concentration (the size of the read-out at that concentration, not a potency): 22%
Beside the measured number, compound 3's estimate is 28 percentage points above it, and the stated range covers the measured number.
By their numbers in this assay, from the lowest: compounds 2 and 3 (each within the scatter of the next); then compound 1.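

In this assay, the change from (3-methoxyphenyl)amino to (4-methoxybenzyl)amino gives a large step, a number 50 percentage points lower from compound 1 to compound 3 (beyond the scatter), so the group on this nitrogen on an aromatic ring matters to the read-out. Compound 1 and compound 2 differ in more than one place and could not show this, whereas compound 1 and compound 3 differ only here, although the group count stays the same: one carbon-only aromatic ring and one hydrogen-bond acceptor on each side. The single step still combines two differences, the extra carbon of the benzyl group and the methoxy group's move from 3 to 4 in the group's name, and nothing shown explains the loss or separates these two differences.

Going by these compounds, it remains open whether 3-methoxybenzyl or unsubstituted benzyl would stand closer to compound 1 or to compound 3, which would help to separate the extra carbon from the place of the methoxy group. Also open, on these data alone, is how a 4-methoxyphenyl group, a longer 2-phenylethyl chain or a non-aromatic amine such as morpholine would fare on this nitrogen.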